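The compounds below may be only part of what the source reports. "The series", "measured", "known", "first", "only" and "open" are said of these compounds alone.

Two compounds of the shared core have numbers in a functional assay on PC-3 cells (Homo sapiens) for inhibition, read by sulforhodamine B assay; on this read-out lower numbers stand for stronger inhibition of growth and higher numbers for weaker inhibition of growth. Compound 1 `Cc1ccc2[nH]c(-c3ccc(-c4ccc(-c5ccc(N(C)C)cc5)cc4)cc3)nc2c1` gives 8120 nM in this assay. Compound 2 `Fc1ccc(-c2ccc(-c3ccc(-c4nc5ccccc5[nH]4)cc3)cc2)cc1` gives 41200 nM in this assay, and it stands highest of the two numbers; its nearest neighbour is compound 1, with a lower number beyond the scatter. Compound 3 `FC(F)(F)Oc1ccc(-c2ccc(-c3ccc(-c4nc5ccccc5[nH]4)cc3)cc2)cc1` has not been measured in this assay. It differs from compound 2 in one place: trifluoromethoxy in place of fluoro on an aromatic carbon.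

For the measured compounds named here, no step between measured compounds links the change from compound 2 to compound 3, so the size of its effect in this assay rests on little. That compound 1 has a larger group at the corresponding place and gives 8120 nM in this assay, a lower number than compound 2, points weakly toward a lower number for compound 3, of a size near the edge of the scatter. Compound 3 is estimated at 22000 nM in this assay, between 7000 nM and 65000 nM, a step of a 1.9-fold lower number from compound 2 to compound 3 (0.27 log units; within the scatter).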

Compound 3, concentration for 50% growth inhibition: 100000 nM
Compound 3: middle estimate off by 4.5-fold (0.66 log units), on the low side; the whole stated range lies below it.
By their numbers in this assay, from the lowest: compound 1; then compound 2; then compound 3.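

Trifluoromethoxy in place of fluoro, on an aromatic carbon para to a large group, gives a 2.4-fold higher number from compound 2 to compound 3 (0.39 log units; beyond the scatter) in this assay. For the compounds shown here, this is the first step read at this position, and it is modest but beyond the scatter. Growth inhibition therefore weakens with this change, so the larger group brings no gain at this place on the shared core, although this rests on a single pair. Nothing at hand bears on the cause of this rise.

Still open, from the compounds shown here alone, is how methoxy, a carboxylic acid or a morpholine at this place would stand against fluoro and trifluoromethoxy. Also open, going by these compounds, is whether the same change would give a step of like size and direction on the core of compound 1, with its added methyl.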